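Allyl in Place of Methylsulfanyl on the Shared Core

A few compounds are considered here, and "the series" means these few. Any claim that something is new, unique, unknown or untested is made for them only; others in the source may bear on it.

The series shares one core, seen in compound 1 `O=C(O)COc1cccc(/C=C/c2nc(-c3ccccc3)c(-c3ccccc3)o2)c1`, which in a functional assay for inhibition, with Homo sapiens as the target (a lower number here means a stronger inhibitor, a higher number a weaker inhibitor), gives 13000 nM. Compound 2 `CCOC(=O)/C(=C\c1cccc(OCC(=O)O)c1)c1nc(-c2ccccc2)c(-c2ccccc2)o1` gives 360 nM in this assay, the lowest of the three numbers. Compound 3 `CSC(Cc1cccc(OCC(=O)O)c1)c1nc(-c2ccccc2)c(-c2ccccc2)o1` gives 1300 nM in this assay; this places compound 3 second highest of the three, with a number clearly above that of compound 2 and clearly below that of compound 1, both gaps lying beyond the usual scatter.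

Compound 4 `C=CCC(Cc1cccc(OCC(=O)O)c1)c1nc(-c2ccccc2)c(-c2ccccc2)o1` has not yet been measured in this assay. It differs from compound 3 in one place: allyl in place of methylsulfanyl on a saturated chain carbon bound to an aromatic carbon and a saturated chain carbon. Going by the values given here, no step between measured compounds matches this change, so nothing directly shows its effect. The account therefore expects a step from compound 3 to compound 4 of a 1.2-fold lower number from compound 3 to compound 4 (0.07 log units; within the scatter), small enough to stay within the scatter, in no firm direction. For compound 4 in this assay the expected value is 1100 nM, with a range from 400 nM to 3500 nM.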

Compound 4, half-maximal inhibitory concentration: 570 nM
The estimate for compound 4 lay 1.9-fold (0.29 log units) above the measured number; low and high end bracket the measured number.
By their numbers in this assay, from the lowest: compounds 2 and 4 (each within the scatter of the next); then compound 3; then compound 1.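

Going by these compounds alone, on a saturated chain carbon bound to an aromatic carbon and a saturated chain carbon, allyl in place of methylsulfanyl gives a 2.3-fold lower number from compound 3 to compound 4 (0.36 log units; beyond the scatter) in this assay and is the first change that can be read in one place. The step is modest but lies beyond the scatter, so this position responds to the group it carries, and the two groups are not interchangeable there. Nothing measured on these compounds explains the step.

The compounds shown leave open whether the double bond of allyl matters or whether a saturated propyl chain would give a similar number. They also leave open how an amine or a hydroxyl group on the same carbon would read in this assay and whether a longer chain would extend the step.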